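The source may hold more compounds than are shown below. What is called first, only, known or untested is meant among the compounds shown, and "the series" means these compounds.

Measured so far in an ADME assay (liver) for metabolic stability, with Liver microsome (Homo sapiens) as the target, read by LC-MS, using microsomes, with a stated time of 30 min, tested at 4 uM; a higher number here means that more of the compound is left, a lower number that less of the compound is left:
- compound 1 `Cc1nc(N2CCN(C)CC2)c2nc(-c3ccccc3Cl)n(CCO)c2n1`: 13%
- compound 2 `CCN1CCN(c2nc(C)nc3c2nc(-c2ccccc2Cl)n3CCOC)CC1`: 31%
- compound 3 `CC(=O)NCCn1c(-c2ccccc2Cl)nc2c(N3CCN(C)CC3)nc(C)nc21`: 0%

Compound 3 stands lowest of the three, and compound 1 and compound 2 both lie above it beyond the scatter. Compound 4 `Cc1nc(N2CCN(C)CC2)c2nc(-c3ccccc3Cl)n(CCN3CCCC3=O)c2n1` follows from compound 3 by one change, 2-oxopyrrolidin-1-yl in place of acetamido on a saturated chain carbon, two bonds along the chain from an aromatic nitrogen. Within the data shown here, one measured step bears on this place: a number 13 percentage points lower from compound 1 to compound 3 (beyond the scatter), modest and beyond the scatter. It involves a different exchange, so it gives only a rough size. No fall is possible because compound 3 reads 0%. A small rise is expected, with a number 7 percentage points higher from compound 3 to compound 4 (within the scatter) as the estimated step. For compound 4 the estimated value is 7%, with an expected range of 0% to 22%.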

Compound 4, percent of the compound remaining: 13%
For compound 4 the middle estimate is 6 percentage points below the measured one; the range from low to high includes it.
By their numbers in this assay, from the lowest: compound 3; then compounds 1 and 4 (each within the scatter of the next); then compound 2.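

In this assay, 2-oxopyrrolidin-1-yl in place of acetamido on a saturated chain carbon, two bonds along the chain from an aromatic nitrogen, gives a number 13 percentage points higher from compound 3 to compound 4 (beyond the scatter). In place of hydroxy, the same group gives no change at the digits printed from compound 1 to compound 4 (within the scatter), so the low reading of compound 3 is not shared by both carbonyl-bearing groups at this place. Nothing available explains the difference between these two groups. Still open, from the compounds shown here alone, is how an amine or a carboxylic acid on this chain would read, and whether a longer chain carrying 2-oxopyrrolidin-1-yl would read the same.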